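Aryl exchange at the weak end of the series

The source may hold more compounds than are shown below. What is called first, only, known or untested is meant among the compounds shown, and "the series" means these compounds.

Measured so far in a functional assay on MDA-MB-231 cells (Homo sapiens) for cytotoxicity, read by MTT assay, with a stated time of 48 h; on this read-out higher numbers stand for weaker inhibition and lower numbers for stronger inhibition
- compound 1 `O=C(NCCCCC(c1ccc(F)cc1)c1ccc(F)cc1)Nc1ccc([N+](=O)[O-])cc1` gives 6470 nM
- compound 2 `O=C(NCCCCC(c1ccc(F)cc1)c1ccc(F)cc1)Nc1ccc(Cl)c(C(F)(F)F)c1` gives 3150 nM
- compound 3 `O=C(NCCCCC(c1ccc(F)cc1)c1ccc(F)cc1)Nc1ccc(Cl)cc1C(F)(F)F` gives > 20000 nM

For compound 3 the entry > 20000 nM is a limit and not a number.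

Compound 4 `O=C(NCCCCC(c1ccc(F)cc1)c1ccc(F)cc1)Nc1ccc(Br)cc1I` carries 4-bromo-2-iodophenyl in place of 4-chloro-2-(trifluoromethyl)phenyl on an amide-type nitrogen. Within the data shown here, two measured steps bear on this change: an at least 3.0-fold higher number from compound 1 to compound 3 (0.49 log units; beyond the scatter) and an at least 6.3-fold higher number from compound 2 to compound 3 (0.80 log units; beyond the scatter). Among the measured compounds shown here, compound 3 is the only measured compound with a 2-substituted phenyl, and compound 4 keeps that pattern, so no step beyond the scatter is expected in this assay. The estimated step is an at least 1.3-fold lower number from compound 3 to compound 4 (0.12 log units; that floor lies within the scatter). The estimate for compound 4 is 15000 nM, with an expected range from 6000 nM to 40000 nM.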

Compound 4, half-maximal inhibitory concentration: > 20000 nM
Compound 4: no number, only a limit; the forecaster's own chance of this, stated with the estimate: 40%; at least 1.3-fold (0.12 log units) between middle value and limit.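

In this assay compound 4 gives > 20000 nM, which is a limit and not a number. With an at least 6.3-fold higher number from compound 2 to compound 4 (0.80 log units; beyond the scatter) and an at least 3.0-fold higher number from compound 1 to compound 4 (0.49 log units; beyond the scatter), the weak end of the series is no longer tied to 4-chloro-2-(trifluoromethyl)phenyl on the amide-type nitrogen, since 4-bromo-2-iodophenyl, which carries neither trifluoromethyl nor chlorine, also sits there. Compound 3 and compound 4 share that limit, so the step between them cannot be read: the limit of > 20000 nM in this assay, at which 2 of the 4 values shown sit.

Going by these compounds, how far apart compound 3 and compound 4 truly lie stays open. Also open, on these data alone, is whether a nitrile or a carboxylic acid in place of the iodine of compound 4 would give a number within the range of the assay.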